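The source may report more compounds than this note shows. Statements on the series, on what has been measured and on what is new or still open speak of the compounds shown alone.

Measured in a functional assay on G-361 cells (Homo sapiens) for inhibition, with a stated time of 72 h; a lower number here means a stronger inhibitor, a higher number a weaker inhibitor:

- Compound 1 `COc1ccccc1-c1ccc(CNc2nc(NC3CCC(N)CC3)nc3c2ncn3C2CCCC2)cc1` gives 545 nM
- Compound 2 `NC1CCC(Nc2nc(NCc3ccc(-c4cccc(F)c4)cc3)c3ncn(C4CCCC4)c3n2)CC1` gives 815 nM
- Compound 3 `NC1CCC(Nc2nc(NCc3ccc(-n4cccn4)cc3)c3ncn(C4CCCC4)c3n2)CC1` gives 220 nM

Compound 3 has the lowest number of the three, and its steps to both others lie beyond the scatter. Compound 4 `Nc1ccccc1CNc1nc(NC2CCC(N)CC2)nc2c1ncn2C1CCCC1` has not yet been measured. It departs from compound 3 in one place: 2-aminophenyl in place of 4-(1H-pyrazol-1-yl)phenyl on a saturated chain carbon bound to a nitrogen on an aromatic ring. This puts 2-aminophenyl in place of 4-(1H-pyrazol-1-yl)phenyl on a saturated chain carbon bound to a nitrogen on an aromatic ring.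

For the measured compounds named here, three measured steps bear on this only loosely, since each changes a group on an aromatic carbon. The first is a 1.5-fold higher number from compound 1 to compound 2 (0.17 log units; within the scatter). The other two are modest: a 2.5-fold lower number from compound 1 to compound 3 (0.39 log units; beyond the scatter) and a 3.7-fold lower number from compound 2 to compound 3 (0.57 log units; beyond the scatter). Going by the values given here, no measured compound shows what happens when the whole group is exchanged at the saturated chain carbon, so the size of this step is uncertain. Compound 3 stands lowest at 220 nM, so a move to a higher number is the more likely outcome, somewhat larger than the modest steps seen so far. The expected step is a 4.1-fold higher number from compound 3 to compound 4 (0.61 log units; beyond the scatter). For compound 4 the estimated value is 900 nM, with an expected range of 250 nM to 3000 nM.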

Compound 4, half-maximal inhibitory concentration: 2070 nM
For compound 4 the middle estimate is 2.3-fold (0.36 log units) below the measured one, within the range that was stated.
By their numbers in this assay, from the lowest: compound 3; then compounds 1 and 2 (each within the scatter of the next); then compound 4.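

In this assay, the exchange of the whole group on the saturated chain carbon bound to a nitrogen on an aromatic ring gives a 9.4-fold higher number from compound 3 to compound 4 (0.97 log units; beyond the scatter). This is larger than any earlier change of a group on an aromatic carbon, the largest of which was a 3.7-fold lower number from compound 2 to compound 3 (0.57 log units; beyond the scatter), so the numbers in this series respond more strongly to this exchange than to those earlier ones. The change replaces 4-(1H-pyrazol-1-yl)phenyl, which has two aromatic rings and no hydrogen-bond donor, with 2-aminophenyl, which has one aromatic ring and 1 hydrogen-bond donor, but no available evidence explains the higher number.

Since ring count, group size and the amine all change in this single step, the compounds shown do not separate their contributions. A plain phenyl or a 2-hydroxyphenyl on the same carbon would help to show whether the higher number goes with the loss of the 1H-pyrazol-1-yl ring or with the entering amine.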